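Pyrrolyl for methylphenyl on the shared core

A few compounds are considered here, and "the series" means these few. Any claim that something is new, unique, unknown or untested is made for them only; others in the source may bear on it.

Three compounds have numbers in a functional assay on MCF7 cells (Homo sapiens) for antiproliferative activity, read by MTT assay, with a stated time of 72 h; on this read-out lower numbers stand for stronger inhibition and higher numbers for weaker inhibition. Compound 2 `C#CCSc1nc(Sc2nccs2)c(C#N)c(-c2ccc(C)cc2)n1` gives 2200 nM in this assay and holds the lowest of the three numbers. Compound 1 `C#CCSc1nc(Sc2nnnn2CCN(C)C)c(C#N)c(-c2cccc(Cl)c2)n1` gives 4120 nM in this assay; its number and that of compound 2 lie within the scatter of each other, so nothing is made of that gap. Within the data shown here, compound 3 `C=CC(=O)Nc1ccccc1CN(C(=O)Nc1cccc(C(F)(F)F)c1)C1CCN(C(C)CCC)CC1` gives 10200 nM in this assay, a number beyond the scatter from that of compound 2; compound 3 is built differently throughout, so the two values show only that compound 3 sits at the weaker end of the pair. Among the measured compounds shown here, no two measured compounds differ in a single place, so no step has been measured.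

Compound 4 `C#CCSc1nc(Sc2nccs2)c(C#N)c(-c2ccc[nH]2)n1` has not yet been measured. It differs from compound 2 in one place: 1H-pyrrol-2-yl in place of 4-methylphenyl on an aromatic carbon. For the measured compounds named here, nothing among the measured compounds shows what exchanging the group on this aromatic carbon does; compound 1 carries a different group there and also differs elsewhere, so its value against compound 2 cannot be read as this change. A step toward a higher number, a 1.6-fold higher number from compound 2 to compound 4 (0.20 log units; within the scatter), is expected, of a size that may not exceed the scatter. The estimate for compound 4 in this assay is 3500 nM, with a range from 1200 nM to 10000 nM.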

Compound 4, half-maximal inhibitory concentration: > 20000 nM
Compound 4: no number, only a limit; the forecaster's own chance of this, stated with the estimate: 5%; middle value at least 5.7-fold (0.75 log units) away from the limit.
By their numbers in this assay, from the lowest: compounds 2 and 1 (each within the scatter of the next); then compound 3. At a limit, above all of these: compound 4.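

Compound 4 reads > 20000 nM in this assay, and this is a limit of the assay and not a number: the limit of > 20000 nM in this assay, at which 1 of the 4 values shown sits.

Among these compounds, with the nitrile, the (1,3-thiazol-2-yl)sulfanyl group and the propargylsulfanyl group all held constant, 1H-pyrrol-2-yl in place of 4-methylphenyl gives an at least 9.0-fold higher number from compound 2 to compound 4 (0.95 log units; beyond the scatter), the only measured step. Among the compounds shown here, the aromatic carbon next to the ring nitrogen and ortho to the cyano group is therefore not indifferent to the group it carries: this single exchange is enough to move the read-out beyond the scatter, which the earlier values, with no step among them, could not show.

The exchange changes several things at once, from a six-membered carbon ring to a five-membered ring with 1 hetero atom and from 0 hydrogen-bond donors to 1, and the two compounds do not separate these changes. A plain phenyl, a 1-methyl-1H-pyrrol-2-yl or a pyridin-3-yl group on the same carbon would show which of them tracks with the step, and whether any group here gives a number lower than that of compound 2.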